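Ring substituent series: from chloro to nitro

A few compounds are considered here, and "the series" means these few. Any claim that something is new, unique, unknown or untested is made for them only; others in the source may bear on it.

Measured compounds in a functional assay on HCT-116 cells (Homo sapiens) for inhibition, read by MTT assay, with a stated time of 72 h; a higher number here means a weaker inhibitor, a lower number a stronger inhibitor:
- compound 1 `COc1ccc2c(c1)/C(=N/NC(=S)N1CCN(c3ccccc3)CC1)C(=O)N2`: 9530 nM
- compound 2 `O=C1Nc2ccc(Br)cc2/C1=N/NC(=S)N1CCN(c2ccccc2)CC1`: 10400 nM
- compound 3 `O=C1Nc2ccc(Cl)cc2/C1=N/NC(=S)N1CCN(c2ccccc2)CC1`: 3490 nM

Compound 3 gives the lowest of the three numbers in this assay. The two steps reaching it both move the number down by a modest amount: a 2.7-fold lower number from compound 1 to compound 3 (0.44 log units; beyond the scatter) and a 3.0-fold lower number from compound 2 to compound 3 (0.47 log units; beyond the scatter). Between the other two compounds there is no change to speak of, a 1.1-fold higher number from compound 1 to compound 2 (0.04 log units; within the scatter).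

Compound 4 `O=C1Nc2ccc([N+](=O)[O-])cc2/C1=N/NC(=S)N1CCN(c2ccccc2)CC1` differs from compound 3 in one place: nitro in place of chloro on an aromatic carbon. For the measured compounds named here, no measured step exchanges chloro for nitro, so the bearing of the earlier steps is indirect. They show that among methoxy, bromo and chloro at this position, only chloro stands apart, and only modestly; a fourth substituent is therefore more likely to sit near compounds 1 and 2 than to go further down. For compound 4 in this assay a modest move upward from compound 3 is expected, a 1.4-fold higher number from compound 3 to compound 4 (0.16 log units; within the scatter), with a wide range. The estimate for compound 4 is 5000 nM, between 1500 nM and 17000 nM.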

Compound 4, half-maximal inhibitory concentration: 15100 nM
Estimate against measurement, compound 4: 3.0-fold (0.48 log units) below; the measured number falls inside the stated range.
By their numbers in this assay, from the lowest: compound 3; then compounds 1, 2 and 4 (each within the scatter of the next).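

In this assay, nitro in place of chloro gives a 4.3-fold higher number from compound 3 to compound 4 (0.64 log units; beyond the scatter), so a third substituent now lies beyond the scatter from compound 3. The other two steps, a 1.5-fold higher number from compound 2 to compound 4 (0.16 log units; within the scatter) and a 1.6-fold higher number from compound 1 to compound 4 (0.20 log units; within the scatter), both stay within the scatter, which places nitro with bromo and methoxy at this position. Among these four compounds, only compound 3 stands apart, and the exchange of one chlorine atom for the three heavy atoms of nitro does not lower the number.

From the compounds shown here alone, whether fluoro, an amine or a carboxylic acid at this position would group with compound 3 or with compounds 1, 2 and 4 remains open. The data shown offer no information on why chloro alone stands apart.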